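The source may report more compounds than this note shows. Statements on the series, on what has been measured and on what is new or still open speak of the compounds shown alone.

Compound 1, with the structure `O=C(/C=C/c1ccc(/C=N/NC(=O)c2ccncc2)cc1)c1cccc(Br)c1`, has the lowest number of the three measured compounds in a functional assay on the whole organism (Ear) for inhibition, with Mus musculus as the target, with a stated time of 30 min, at a dose of 100 mg/kg by the intraperitoneal route (a lower number here means less inhibition, a higher number more inhibition at the dose given (going by the name of the read-out)), where compound 1 gives 14%. Compound 2, `N=C(N)N/N=C/c1ccc(/C=C/C(=O)c2cccc(Br)c2)cc1`, reaches 49.7%, and compound 3, `O=C(/C=C/c1ccc(/C=N/NC(=O)c2ccncc2)cc1)c1ccc(F)cc1`, reaches 51.1%. Both steps away from compound 1 were large: a number 35.7 percentage points higher from compound 1 to compound 2 (beyond the scatter), and a number 37.1 percentage points higher from compound 1 to compound 3 (beyond the scatter).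

Compound 4, `O=C(/C=C/c1ccc(/C=N/NC(=O)c2ccncc2)cc1)c1ccc(Br)cc1`, is built from the same atoms as compound 1 but joined differently: 4-bromophenyl in place of 3-bromophenyl on a carbonyl carbon. For the measured compounds named here, only one measured step touches the same part of the molecule, the group on the carbonyl carbon, and that is the step to compound 3, where 4-fluorophenyl replaced 3-bromophenyl and this assay rose strongly. The change to compound 4 is smaller in kind, since the bromine stays and only the ring it sits on is rearranged, so a rise is plausible but its size is uncertain.

The expectation for compound 4 is therefore a moderate rise, a number 21 percentage points higher from compound 1 to compound 4 (beyond the scatter), an estimate and not a measurement. Compound 4 is expected to give about 35% in this assay, most likely between 15% and 55%.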

Compound 4, a percentage reported as inhibition, in the whole organism at one dose (the size of the read-out at that dose, not a potency): 55.7%
Compound 4: the middle estimate sits 20.7 percentage points below what was measured, and the stated range ends below it.
By their numbers in this assay, from the lowest: compound 1; then compounds 2, 3 and 4 (each within the scatter of the next).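

Moving the bromine alone, with the atoms unchanged, is enough to shift this assay: 4-bromophenyl in place of 3-bromophenyl on the carbonyl carbon gives a number 41.7 percentage points higher from compound 1 to compound 4 (beyond the scatter), so where the bromine sits on this ring matters and not merely that it is there. The earlier step to compound 3 changed both the halogen and its place at once, and the new step of a number 4.6 percentage points higher from compound 3 to compound 4 (within the scatter) separates the two, showing that bromo in place of fluoro on this aromatic carbon makes no readable difference between these two compounds. The 3-bromophenyl group does not settle the outcome on its own, however, since compound 2 carries it too and still gives 49.7% in a molecule that differs from compound 1 at the other end.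

Nothing measured here explains why the place of the bromine counts so much. The compounds shown leave open whether 3-fluorophenyl would give a low number like compound 1, and whether 4-chlorophenyl, 4-methoxyphenyl or 4-aminophenyl on the carbonyl carbon would hold the level of compound 3 and compound 4.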